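A Fluoro Swap on a Compound at the Limit

A few compounds are considered here, and "the series" means these few. Any claim that something is new, unique, unknown or untested is made for them only; others in the source may bear on it.

Of the compounds shown here, three have been measured so far in a functional assay on L6 cells (Rattus norvegicus) for cytotoxicity; a lower number here means a stronger inhibitor, a higher number a weaker inhibitor. Compound 1 `N=C(N)c1ccc(-c2ccc(-c3ccc(C(=N)N)cc3)c(F)c2)cc1` gives 6400 nM. Compound 2 `N=C(N)c1ccc(-c2ccc(-c3ccc(C(=N)N)o3)cc2)cc1` gives 56100 nM. Compound 3 `N=C(NO)c1ccc(-c2ccc(-c3ccc(/C(N)=N\O)cc3)cc2)cc1` stands at the limit of > 211000 nM in this assay, at which 1 of the 3 values shown sits, so its result of > 211000 nM is a limit and not a number.

The next compound to be tested is compound 4 `N=C(NO)c1ccc(-c2ccc(-c3ccc(/C(N)=N\O)cc3)cc2F)cc1`. It differs from compound 3 in a single place: fluoro in place of hydrogen on an aromatic carbon. This is fluoro in place of hydrogen on an aromatic carbon, in a six-membered aromatic ring of carbon only, ortho to a large group and meta to a large group.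

Among the compounds with values here, no two measured compounds differ in just one place, so the data hold no direct measure of what such a swap does in this assay. The expectation is therefore cautious. Starting from the limit of > 211000 nM for compound 3, a small move toward a stronger inhibitor is expected, and it may well stay within the scatter. The expected size of the change is an at least 1.4-fold lower number from compound 3 to compound 4 (0.14 log units; that floor lies within the scatter). For compound 4 the estimated value is 150000 nM, with an expected range from 40000 nM to 300000 nM.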

Compound 4, half-maximal inhibitory concentration: 29100 nM
Estimate against measurement, compound 4: 5.2-fold (0.71 log units) above; measured number outside the range, below it.
By their numbers in this assay, from the lowest: compound 1; then compounds 4 and 2 (each within the scatter of the next). At a limit, above all of these: compound 3.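

In this assay, fluoro in place of hydrogen on this aromatic carbon, ortho to a large group and meta to a large group, gives the first direct measure of a single change in this set: an at least 7.2-fold lower number from compound 3 to compound 4 (0.86 log units; beyond the scatter). That size is a floor and not an exact figure, because the starting point for compound 3 is a limit and not a number: the limit of > 211000 nM in this assay, at which 1 of the 4 values shown sits.
Even so, the smallest possible change of one heavy atom, with no ring and no net charge added, is enough to give a measured result, and compound 4 gives 29100 nM, a true number that later changes can be measured against.

The compounds shown leave open whether this step belongs to fluoro itself or to any group at this place, a question that chloro, methyl or methoxy on the same carbon would help to settle. They also leave open whether fluoro on the other aromatic carbons of this ring, or the same swap on a compound that starts from a true number and not from a limit, would give a step of similar size.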